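From 4-ethylphenyl to 4-ethoxyphenyl on the shared core

The compounds below may be only part of what the source reports. "The series", "measured", "known", "first", "only" and "open" are said of these compounds alone.

In a functional assay on A2780 cells (Homo sapiens) for antiproliferative activity, read by resazurin assay, with a stated time of 72 h (on this read-out lower numbers stand for stronger inhibition and higher numbers for weaker inhibition), compound 1 (`CN(Cc1cccc(Br)c1)C(=O)c1cc2c(Cc3ccccc3)n[nH]c2cc1O`) gives 7100 nM and compound 2 (`CCc1ccc(CN(C)C(=O)c2cc3c(Cc4ccccc4)n[nH]c3cc2O)cc1`) gives 9400 nM. For the measured compounds named here, these two numbers lie within the scatter of each other, so compound 2 stands level with the only other measured compound. Compound 3 (`CCOc1ccc(CN(C)C(=O)c2cc3c(Cc4ccccc4)n[nH]c3cc2O)cc1`) differs from compound 2 in one place, with ethoxy in place of ethyl on an aromatic carbon, para to a large group: ethoxy in place of ethyl on an aromatic carbon. Going by the values given here, the one measured step on this part of the structure, a 1.3-fold higher number from compound 1 to compound 2 (0.12 log units; within the scatter), exchanged 3-bromophenyl for 4-ethylphenyl and stayed within the scatter. Among the compounds with values here, that single step is thin evidence, and no measured compound yet carries the ethoxy group. No change beyond the scatter is therefore expected in this assay. The expected step is a 1.2-fold lower number from compound 2 to compound 3 (0.07 log units; within the scatter). For compound 3 the estimated value is 8000 nM, with an expected range from 3500 nM to 18000 nM.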

Compound 3, half-maximal inhibitory concentration: 3200 nM
Estimate against measurement, compound 3: 2.5-fold (0.40 log units) above; the measured number lies below the stated range.
By their numbers in this assay, from the lowest: compound 3; then compounds 1 and 2 (each within the scatter of the next).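

In this assay, for the compounds shown here, this position proves sensitive to its substituent for the first time, with a 2.9-fold lower number from compound 2 to compound 3 (0.47 log units; beyond the scatter) when ethoxy replaces ethyl on the aromatic carbon para to a large group. The 4-ethoxyphenyl group also stands apart from the 3-bromophenyl group, with a 2.2-fold lower number from compound 1 to compound 3 (0.35 log units; beyond the scatter), whereas the earlier exchange of 3-bromophenyl for 4-ethylphenyl stayed within the scatter. No measurement available here accounts for this stronger inhibition.

The compounds shown leave open whether the step belongs to the added oxygen or to the longer group, a question that a propyl group or a methoxy group in the same place would help to settle. They also leave open whether an ethoxy group would give a similar step on a different core.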